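This account rests on a few compounds, and the source may have more. Where it says the series, first, only, none or still open, it means among the compounds named here.

Of the compounds shown here, three have so far been measured in a functional assay on MDA-MB-435S cells (Homo sapiens) for antiproliferative activity, read by MTT assay, with a stated time of 72 h; on this read-out lower numbers stand for stronger inhibition and higher numbers for weaker inhibition. Compound 1 `Cc1ccc2c(=O)c(CSC(=S)N3CCCCC3)coc2c1` gives 1700 nM in this assay. Compound 3 `COc1ccc2oc(CSC(=S)N3CCCCC3)cc(=O)c2c1` gives 1500 nM, a number so close to that of compound 1 that the two cannot be told apart within the usual scatter. Compound 2 `O=c1c(CSC(=S)N2CCN(c3ccccc3)CC2)coc2ccccc12` gives 9700 nM, a higher number than compound 1 by a margin beyond the scatter, meaning it inhibits the cells less strongly. Compound 1 therefore holds the second highest of the three numbers, sitting together with compound 3 and clearly apart from compound 2.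

Compound 4 `Cc1ccc2c(=O)c(CSC(=S)N3CCCC3)coc2c1` has not yet been measured. It differs from compound 1 in a single place: pyrrolidin-1-yl in place of piperidin-1-yl on a thiocarbonyl carbon. Among the measured compounds shown here, no measured pair shows what this exchange of one saturated nitrogen ring for another does in this assay, so the expectation rests on the smallness of the change alone. A step of no size beyond the scatter is expected, in either direction. The expected step is a 1.1-fold higher number from compound 1 to compound 4 (0.02 log units; within the scatter). Compound 4 is accordingly estimated to give 1800 nM, with a range from 700 nM to 4500 nM.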

Compound 4, half-maximal inhibitory concentration: 1900 nM
For compound 4 the middle estimate is 1.1-fold (0.02 log units) below the measured one; the range from low to high includes it.
By their numbers in this assay, from the lowest: compounds 3, 1 and 4 (each within the scatter of the next); then compound 2.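

In this assay, exchanging piperidin-1-yl for pyrrolidin-1-yl on a thiocarbonyl carbon gives a 1.1-fold higher number from compound 1 to compound 4 (0.05 log units; within the scatter). Among the compounds shown here, this is the first pair here that differs in one place only, and it shows that on the core of compound 1, this position accepts the five-membered ring as well as the six-membered one, with no change that can be told from the scatter. Nothing available bears on what lies behind this result.

Still open, going by these compounds, is whether the position stays this accepting of a ring with a second hetero atom, such as morpholine, a larger ring such as azepane, or an open-chain group such as diethylamino. A single pair also cannot tell whether the same exchange would behave alike on the core of compound 3.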